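Swapping a ring for an open chain on a weak inhibitor

The source may hold more compounds than are shown below. What is called first, only, known or untested is meant among the compounds shown, and "the series" means these compounds.

The shared core of compound 1 `COc1ccc(/C=C\c2cc(OC)c(OC)c(OC)c2)cc1OCc1ccc(CN2CCCC[C@H]2C(=O)O)cc1` carries, on a saturated chain carbon bound to an aromatic carbon, a 2-carboxypiperidin-1-yl group. In a functional assay on HeLa cells (Homo sapiens) for antiproliferative activity, read by CCK-8 assay, with a stated time of 48 h (on this read-out lower numbers stand for stronger inhibition and higher numbers for weaker inhibition), compound 1 gives > 10000 nM, which is a limit of the assay and not a measured number. Compound 2 `COc1ccc(/C=C\c2cc(OC)c(OC)c(OC)c2)cc1OCc1ccc(CO)cc1` differs from compound 1 only in having hydroxy in place of 2-carboxypiperidin-1-yl at that same position, and in this assay compound 2 gives 7600 nM. The step of an at least 1.3-fold lower number from compound 1 to compound 2 (0.11 log units; that floor lies within the scatter) is therefore small and rests on a limit (the limit of > 10000 nM in this assay, at which 1 of the 2 values shown sits), so it says little about direction.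

Compound 3 `COc1ccc(/C=C\c2cc(OC)c(OC)c(OC)c2)cc1OCc1ccc(CNCCNC(C)=O)cc1` is the compound not yet measured. It differs from compound 1 in this way: (2-acetamidoethyl)amino in place of 2-carboxypiperidin-1-yl on a saturated chain carbon bound to an aromatic carbon. Within the data shown here, the only measured step at this position, from compound 1 to compound 2, was small, so no step beyond the scatter is expected for compound 3 either. For compound 3 the expected step is an at least 1.2-fold lower number from compound 1 to compound 3 (0.09 log units; that floor lies within the scatter). Compound 3 is thus estimated at 8000 nM, within a range from 3000 nM to 20000 nM.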

Compound 3, half-maximal inhibitory concentration: 6400 nM
For compound 3 the middle estimate is 1.3-fold (0.10 log units) above the measured one; measured number inside the range.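

In this assay, compound 3 gives a second measured number at this position, so one comparison here no longer rests on a limit. That comparison is a 1.2-fold lower number from compound 2 to compound 3 (0.07 log units; within the scatter), which means that (2-acetamidoethyl)amino and hydroxy, on a saturated chain carbon bound to an aromatic carbon, cannot be told apart in this assay, even though the two groups differ clearly in what they contain. The other comparison, an at least 1.5-fold lower number from compound 1 to compound 3 (0.19 log units; that floor lies within the scatter), gives no firm size or direction, since compound 1 is known only through a limit: the limit of > 10000 nM in this assay, at which 1 of the 3 values shown sits.

The compounds shown leave open whether any group at this position can move the number beyond the scatter, and in which direction. A simple primary amine, a morpholine ring or a carboxylic acid on a longer chain, set on the same saturated chain carbon, would show whether the number here can differ clearly from those of compound 2 and compound 3, and a true number for compound 1 would show how far its 2-carboxypiperidin-1-yl group stands from them.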